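Swapping tert-butyl for benzyl on the side-chain amine

The compounds below may be only part of what the source reports. "The series", "measured", "known", "first", "only" and "open" are said of these compounds alone.

Measured so far in a functional assay on SK-BR-3 cells (Homo sapiens) for antiproliferative activity; a higher number here means a weaker inhibitor, a lower number a stronger inhibitor:
compound 1, `CC(C)=CCc1cc(C(=O)Nc2cc3ccc(OCCCN4CCCCC4)c(C)c3oc2=O)ccc1O`: > 50000 nM.
compound 2, `CC(C)=CCc1cc(C(=O)Nc2cc3ccc(OCCCN(C)C(C)(C)C)c(C)c3oc2=O)ccc1O`: 880 nM.

For compound 1 the result is only a limit of this assay, (the limit of > 50000 nM in this assay, at which 1 of the 2 values shown sits). Among the measured compounds shown here, compound 2 gives 880 nM in this assay, the only actual number among the two values shown, so it is the sole anchor. For the measured compounds named here, the single measured step, an at least 56-fold lower number from compound 1 to compound 2 (1.75 log units; beyond the scatter), is a change at the same amine and shows that alterations there can move the number a great deal. Compound 3, `CC(C)=CCc1cc(C(=O)Nc2cc3ccc(OCCCN(C)Cc4ccccc4)c(C)c3oc2=O)ccc1O`, differs from compound 2 in one place: benzyl in place of tert-butyl on an amine nitrogen. That measured step does not tell which way a benzyl will move the number. Since compound 3 keeps the acyclic methyl-amine of compound 2, a modest step is expected, a 1.7-fold higher number from compound 2 to compound 3 (0.23 log units; within the scatter), with a wide spread. Compound 3 is estimated at 1500 nM in this assay, between 300 nM and 8000 nM.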

Compound 3, half-maximal inhibitory concentration: 10700 nM
Beside the measured number, compound 3's estimate is 7.1-fold (0.85 log units) below it; measured number outside the range, above it.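

In this assay, keeping the open-chain methyl amine is not enough to hold the number near that of compound 2, since the group that shares the nitrogen still decides a great deal, with a 12-fold higher number from compound 2 to compound 3 (1.08 log units; beyond the scatter). Tert-butyl, benzyl and piperidin-1-yl thus fall into a clear order at this amine, with the benzyl(methyl)amino group lying on the weaker side of methyl(tert-butyl)amino but on the stronger side of piperidin-1-yl, with an at least 4.6-fold lower number from compound 1 to compound 3 (0.66 log units; beyond the scatter). That second step can only be read as a minimum, as compound 1 gives a limit and not a number: the limit of > 50000 nM in this assay, at which 1 of the 3 values shown sits.

On these data alone, what an isopropyl or a cyclopropyl in place of tert-butyl on the same amine nitrogen would give stays open. So does whether the advantage of tert-butyl over benzyl would survive a longer chain between the ring oxygen and the amine.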